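Neopentyloxy in Place of Pyrrolidinyl on Compound 2

The compounds below may be only part of what the source reports. "The series", "measured", "known", "first", "only" and "open" are said of these compounds alone.

In an assay on cells for antagonist activity at transient receptor potential cation channel subfamily V member 1 (Homo sapiens), read by FLIPR and calcium flux, with a stated time of 6 min (on this read-out lower numbers stand for stronger inhibition and higher numbers for weaker inhibition), compound 1 `CC(C(=O)NCc1ccc(C(C)(C)C)nc1N1CCCC1)c1ccc(NS(C)(=O)=O)c(F)c1` gives 1.2 nM, while compound 2 `CC(C(=O)NCc1ccc(C(C)(C)C)cc1N1CCCC1)c1ccc(NS(C)(=O)=O)c(F)c1` gives 8.1 nM, the higher of the two numbers, with a gap that lies beyond the usual scatter. Compound 3 `CC(C(=O)NCc1ccc(C(C)(C)C)cc1OCC(C)(C)C)c1ccc(NS(C)(=O)=O)c(F)c1` has not yet been measured. It differs from compound 2 in a single place: neopentyloxy in place of pyrrolidin-1-yl on an aromatic carbon. For the measured compounds named here, no measured pair shows this change, so its effect remains open. The step from compound 2 to compound 3 is expected to be small, within or barely beyond the scatter, a 1.2-fold higher number from compound 2 to compound 3 (0.09 log units; within the scatter). Compound 3 is estimated at 10 nM, in a range from 3 nM to 40 nM.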

Compound 3, inhibition constant: 3.8 nM
Estimate against measurement, compound 3: 2.6-fold (0.42 log units) above; the measured number falls inside the stated range.
By their numbers in this assay, from the lowest: compound 1; then compound 3; then compound 2.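

In this assay, neopentyloxy in place of pyrrolidin-1-yl on this aromatic carbon gives a 2.1-fold lower number from compound 2 to compound 3 (0.33 log units; beyond the scatter), a modest step. The position therefore accepts a group with no ring, joined through oxygen rather than nitrogen, without any loss of inhibition. Nothing available explains this gain. Still open, going by these compounds, is how a shorter ether such as methoxy or an amine such as piperidin-1-yl would read at this position. Also open, on these data alone, is whether neopentyloxy would bring a similar step on the core of compound 1.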